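This account rests on a few compounds, and the source may have more. Where it says the series, first, only, none or still open, it means among the compounds named here.

Measured compounds:
compound 1, `CCCCCCCCCCC(C)(C)C(=O)Nc1c(C)cccc1OC`, giving 210 nM in an assay on microsomes from intestine for inhibition of acyl-CoA:cholesterol acyltransferase (Oryctolagus cuniculus); a higher number here means a weaker inhibitor, a lower number a stronger inhibitor
compound 2, `CCCCCCCCCCC(C)(C)C(=O)Nc1c(C)cccc1C(C)C`, giving 240 nM in this assay

Compound 2 has the highest of the two numbers recorded so far, but its nearest neighbour, compound 1, lies within the scatter of repeated measurements, so the two cannot be told apart: the step of a 1.1-fold higher number from compound 1 to compound 2 (0.06 log units; within the scatter) shows that swapping one small group for another on the ring left the result essentially unchanged.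

Compound 3, `CCCCCCCCCCC(C)(C)C(=O)Nc1c(C(C)C)cccc1C(C)C`, is not yet measured. It differs from compound 2 by one change: isopropyl in place of methyl on an aromatic carbon. For the measured compounds named here, this resembles the only measured step in that a small group on the aromatic ring is exchanged for a larger one; that step, a 1.1-fold higher number from compound 1 to compound 2 (0.06 log units; within the scatter), stayed within the scatter. On that single precedent no shift beyond the scatter is expected in this assay for compound 3, in either direction, although a single step is thin ground for confidence.

Compound 3 is therefore estimated at 240 nM, with a range from 100 nM to 600 nM, which means an expected step of no change at the digits printed from compound 2 to compound 3 (within the scatter).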

Compound 3, half-maximal inhibitory concentration: 210 nM
Estimate against measurement, compound 3: 1.1-fold (0.06 log units) above; the measured number falls inside the stated range.
By their numbers in this assay, from the lowest: compounds 1, 3 and 2 (each within the scatter of the next).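

In this assay, isopropyl in place of methyl on this aromatic carbon, ortho to a large group and meta to an isopropyl group, gives a 1.1-fold lower number from compound 2 to compound 3 (0.06 log units; within the scatter), so the two compounds cannot be told apart. The earlier step, a 1.1-fold higher number from compound 1 to compound 2 (0.06 log units; within the scatter), concerned the other substituted ring carbon; this result adds that a group of 3 heavy atoms can replace one of 1 heavy atom at this second place with no change that the assay can resolve, and compound 3 carries isopropyl at both places. No measurement is available that would explain why the number holds steady across this change.

At this position, only methyl and isopropyl are shown, both made of carbon and hydrogen alone, so it remains open whether an amine, a carboxylic acid or a methoxy group here would leave the number as undisturbed. Going by these compounds, the long chain and the amide stay the same throughout, so it is also open how a shorter chain, or a ring in place of that chain, would read alongside these ring groups.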